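A few compounds are considered here, and "the series" means these few. Any claim that something is new, unique, unknown or untested is made for them only; others in the source may bear on it.

Of the compounds shown here, three sharing one core have been tested in a functional assay on MCF7 cells (Homo sapiens) for inhibition; on this read-out lower numbers stand for stronger inhibition of growth and higher numbers for weaker inhibition of growth. Compound 1 `O=C(OC1CCCCC1)c1ccsc1NC(=O)[C@@H]1CCCN1` gives 162 ug/mL. Compound 2 `COC(=O)c1sccc1NC(=O)[C@@H]1CCCN1` gives 163 ug/mL, and compound 3 `COC(=O)c1ccsc1NC(=O)[C@H]1CCCN1` gives 179 ug/mL. Of these three numbers, that of compound 1 is the lowest, but its gap to compound 2 and its gap to compound 3 both lie within the usual scatter of repeated measurements, so the three compounds cannot be told apart on this read-out; all three inhibit growth only weakly.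

The next compound, compound 4 `O=C(OCC(Cl)(Cl)Cl)c1ccsc1NC(=O)[C@@H]1CCCN1`, is built from compound 1 by a single change: 2,2,2-trichloroethyl in place of cyclohexyl on an oxygen next to a carbonyl group. The cyclohexyl group leaves and 2,2,2-trichloroethyl enters on the oxygen next to the carbonyl group. For the measured compounds named here, no pair of compounds measured so far differs in exactly one place, so there is no measured step to lean on. What the numbers do show is that compounds 1, 2 and 3, although they differ from one another in more than one place, sit close together. On that basis the step from compound 1 to compound 4 is expected to be of no size beyond the scatter, in either direction. The expected step of a 1.0-fold higher number from compound 1 to compound 4 (0.01 log units; within the scatter) is therefore small. Compound 4 is thus estimated to give 165 ug/mL, with a range from 80 ug/mL to 340 ug/mL.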

Compound 4, concentration for 50% growth inhibition: > 250 ug/mL
Compound 4: only a limit was reported; the forecaster's own chance of this, stated with the estimate: 15%; middle value at least 1.5-fold (0.18 log units) away from the limit.
By their numbers in this assay, from the lowest: compounds 1, 2 and 3 (each within the scatter of the next). At a limit, above all of these: compound 4.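

In this assay compound 4 gives > 250 ug/mL, which is a limit of the assay and not a number. For the compounds shown here, replacing cyclohexyl with 2,2,2-trichloroethyl on the oxygen next to a carbonyl group is the first change here that can be read on its own, and it gives an at least 1.5-fold higher number from compound 1 to compound 4 (0.18 log units; that floor lies within the scatter). The result shows that this exchange brings no gain in growth inhibition, but it cannot show a real loss, as the floor of the step lies within the scatter and the reading of compound 4 stops at a limit: the limit of > 250 ug/mL in this assay, at which 1 of the 4 values shown sits.

The compounds shown leave open how far compound 4 truly lies from compound 1, and therefore whether this exchange weakens growth inhibition at all. They also leave open whether any other group on this oxygen would give stronger inhibition of growth than the cyclohexyl group of compound 1, for example a benzyl group or a longer chain such as n-octyl, or whether an amine in place of this oxygen would change the picture.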